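This account rests on a few compounds, and the source may have more. Where it says the series, first, only, none or still open, it means among the compounds named here.

Compound 1: `COC(=O)CCNC(=O)[C@@H]1CC=C(CCC=C(C)C)C[C@H]1c1ccccc1` — > 23000 nM
Compound 2: `COC(=O)CCNC(=O)[C@H]1CC=C(CCC=C(C)C)C[C@@H]1c1ccccc1` — 3100 nM
Compound 3: `CC1(C)CCCC2=C1C[C@H](C(=O)O)[C@@H](c1ccccc1)C2` — > 23000 nM

In an assay on isolated protein for inhibition of Apoptosis regulator Bcl-2 (Homo sapiens), read by fluorescence polarization, with stated times of 5 min and 10 min (a higher number here means a weaker inhibitor, a lower number a stronger inhibitor), compound 1 gives > 23000 nM, and this value is a limit of the assay rather than a number. Compound 2, its mirror image, gives 3100 nM in this assay. That step, an at least 7.4-fold lower number from compound 1 to compound 2 (0.87 log units; beyond the scatter), is the only one measured here, and it rests solely on (the fact that compounds 1 and 2 differ only in the configuration as drawn). Compound 3 also gives a limit, > 23000 nM, in this assay. Compound 1 thus stands at the weak end of what is shown, a point underlined by the limit of > 23000 nM in this assay, at which 2 of the 3 values shown sit.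

Compound 4, `CC(C)=CCCC1=CC[C@@H](C(=O)NCCC(=O)O)[C@H](c2ccccc2)C1`, differs from compound 1 by hydrogen in place of methyl on an oxygen next to a carbonyl group. No measured step involves a change of this kind, so none of the shown data bears directly on it. With compound 1 resting at the limit, compound 4 is expected to stay near that limit, an estimated 30000 nM with a range from 8000 nM to 100000 nM. The expected step is therefore a step that the limit leaves unreadable from compound 1 to compound 4, with a strong chance that only a limit is reported again.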

Compound 4, inhibition constant: > 23000 nM
Compound 4: a limit, no number (the forecaster's own chance of this, stated with the estimate: 70%); the middle value is on the limit's open side.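

In this assay compound 4 reads only as a limit of the assay, as compound 1 does, so the step between the two cannot be read. The compounds shown leave open whether hydrogen in place of methyl on this oxygen changes inhibition at all.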